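Phenylcarbamoyl in place of cyclopropylsulfonyl: working notes

The source may report more compounds than this note shows. Statements on the series, on what has been measured and on what is new or still open speak of the compounds shown alone.

Measured in a functional assay on MDA-MB-231 cells (Homo sapiens) for antiproliferative activity, read by MTT assay, with a stated time of 48 h; a lower number here means a stronger inhibitor, a higher number a weaker inhibitor:
- compound 1 `C=CS(=O)(=O)N1CCN(c2ncnc3sc(-c4ccc(N5CCN(C)CC5)cc4)cc23)CC1` gives 7550 nM
- compound 2 `CN1CCN(c2ccc(-c3cc4c(N5CCN(S(=O)(=O)C6CC6)CC5)ncnc4s3)cc2)CC1` gives 11500 nM

Going by the values given here, compound 2 and compound 1 lie within the scatter of each other, and no other measured compound places them further. The next compound is compound 3 `CN1CCN(c2ccc(-c3cc4c(N5CCN(C(=O)Nc6ccccc6)CC5)ncnc4s3)cc2)CC1`, not yet measured. Its change from compound 2 is phenylcarbamoyl in place of cyclopropylsulfonyl on an amine nitrogen in a ring. Among the compounds with values here, only one measured step bears on this, a 1.5-fold higher number from compound 1 to compound 2 (0.18 log units; within the scatter), a cyclopropyl in place of vinyl on a sulfonyl sulfur. That step keeps the sulfonyl, so the data hold no measured replacement of it. No shift beyond the scatter in this assay is therefore expected, and no direction is favoured, though the uncertainty is wide. The estimated step is a 1.3-fold lower number from compound 2 to compound 3 (0.11 log units; within the scatter). For compound 3 the expected value is 9000 nM, within an estimated range of 3000 nM to 27000 nM.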

Compound 3, half-maximal inhibitory concentration: 7590 nM
Estimate against measurement, compound 3: 1.2-fold (0.07 log units) above, within the range that was stated.
By their numbers in this assay, from the lowest: compounds 1, 3 and 2 (each within the scatter of the next).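

Phenylcarbamoyl is the first replacement of the sulfonyl on this amine nitrogen in a ring to be read in this assay, and it gives a 1.5-fold lower number from compound 2 to compound 3 (0.18 log units; within the scatter) against cyclopropylsulfonyl and a 1.0-fold higher number from compound 1 to compound 3 (0.00 log units; within the scatter) against vinylsulfonyl. In these compounds, then, exchanging the sulfonyl for a carbonyl-linked group with a six-membered aromatic ring and a hydrogen-bond donor moves the number no further than the scatter. Nothing available gives a reason for this insensitivity.

Going by these compounds, it remains open whether a smaller group such as acetyl, a free amine hydrogen, or a carboxylic acid on this nitrogen would move the number beyond the scatter. Also open, on these data alone, is whether a methoxy or chloro group on the phenyl ring of phenylcarbamoyl would do so.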